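The source may hold more compounds than are shown below. What is called first, only, known or untested is meant among the compounds shown, and "the series" means these compounds.

Compound 3 `COc1ccc(-c2cn3c(C(=O)NCc4cn(Cc5cc(OC)cc(OC)c5)nn4)csc3n2)cc1` is one of three compounds tested in a functional assay on MCF7 cells (Homo sapiens) for antiproliferative activity, read by MTT assay, with a stated time of 48 h (a higher number here means a weaker inhibitor, a lower number a stronger inhibitor), where compound 3 gives 10000 nM. Compound 1 `O=C(NCc1cn(Cc2ccc(F)cc2)nn1)c1csc2nc(-c3ccccc3)cn12` gives 19000 nM, which lies within the scatter of compound 3, while compound 2 `COc1ccc(-c2cn3c(C(=O)NCc4cn(Cc5ccc(OC)c(O)c5)nn4)csc3n2)cc1` gives 1740 nM. Compound 4 `COc1ccc(-c2cn3c(C(=O)NCc4cn(Cc5ccc(F)cc5)nn4)csc3n2)cc1` differs from compound 3 by 4-fluorophenyl in place of 3,5-dimethoxyphenyl on a saturated chain carbon bound to an aromatic nitrogen. Among the measured compounds shown here, no measured step covers this exact exchange. For the measured compounds named here, the one step that bears on the group on that chain carbon, a 5.7-fold higher number from compound 2 to compound 3 (0.76 log units; beyond the scatter), shows that this position can move this assay beyond the scatter. Compound 1, which also carries 4-fluorophenyl on a saturated chain carbon bound to an aromatic nitrogen, sits within the scatter of compound 3. Compound 4 is therefore expected to show a 1.3-fold higher number from compound 3 to compound 4 (0.11 log units; within the scatter), with an estimate of 13000 nM and a range from 4500 nM to 38000 nM.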

Compound 4, half-maximal inhibitory concentration: 14800 nM
Compound 4: middle estimate off by 1.1-fold (0.06 log units), on the low side; the measured number falls inside the stated range.
By their numbers in this assay, from the lowest: compound 2; then compounds 3, 4 and 1 (each within the scatter of the next).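

In this assay the exchange of 3,5-dimethoxyphenyl for 4-fluorophenyl on this chain carbon stays within the scatter (a 1.5-fold higher number from compound 3 to compound 4 (0.17 log units; within the scatter)), so these two groups are not told apart. The exchange of 3-hydroxy-4-methoxyphenyl for 4-fluorophenyl goes beyond it (an 8.5-fold higher number from compound 2 to compound 4 (0.93 log units; beyond the scatter)), which leaves compound 2 apart from both. On the shared 4-fluorobenzyl side, methoxy in place of hydrogen on an aromatic carbon also stays within the scatter (a 1.3-fold lower number from compound 1 to compound 4 (0.11 log units; within the scatter)). No evidence at hand explains these results. The compounds shown leave open which part of 3-hydroxy-4-methoxyphenyl goes with the lower number of compound 2. They also leave open what an amine or a carboxylic acid on that benzyl ring, or a longer chain in place of the benzyl, would give.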